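Losing One Side Chain from the Core of Compound 1

The source may report more compounds than this note shows. Statements on the series, on what has been measured and on what is new or still open speak of the compounds shown alone.

Going by the values given here, in a functional assay on DU-145 cells (Homo sapiens) for antiproliferative activity, read by WST assay, with a stated time of 72 h (on this read-out lower numbers stand for an effect already at smaller amounts and higher numbers for an effect only at larger amounts of compound), compound 1 (`CCCCCCCC/C=C/c1c(C)c(/C=C/CCCCCCCC)c2[n+](c1C)CCC2`) gives 0.8 uM and compound 2 (`CCCCCCCC/C=C\c1c(C)c(/C=C/CCCCCCCC)c(C)[n+]2c1CCC2`) gives 0.8 uM, so compound 1 stands level with its only measured neighbour. Compound 3 (`CCCCCCCC/C=C/c1c(C)cc(C)[n+]2c1CCC2`) differs from compound 1 in another way: a hydrogen atom in place of a group of 10 heavy atoms (10 carbon; no ring), on an aromatic carbon. In words, a hydrogen atom stands in place of a group of 10 heavy atoms, on an aromatic carbon. Among the compounds with values here, the one measured step, no change at the digits printed from compound 1 to compound 2 (within the scatter), concerns only (the fact that compounds 1 and 2 differ only in the configuration as drawn), so it bears on the drawn geometry and not on losing the group. Within the data shown here, no measured step removes such a group, and the size of this change is poorly bounded. Starting from compound 1 at 0.8 uM, a moderate move toward higher numbers in this assay is expected. The estimated step is a 3.8-fold higher number from compound 1 to compound 3 (0.57 log units; beyond the scatter). Compound 3 is estimated at 3 uM, within an expected range from 0.8 uM to 12 uM.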

Compound 3, concentration for half-maximal effect: 0.6 uM
The estimate for compound 3 lay 5.0-fold (0.70 log units) above the measured number, outside the stated range (below it).
By their numbers in this assay, from the lowest: compounds 3, 1 and 2 (each within the scatter of the next).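

In this assay, replacing the group of 10 heavy atoms on this aromatic carbon with a hydrogen atom gives a 1.3-fold lower number from compound 1 to compound 3 (0.12 log units; within the scatter). Compound 3 keeps only one of the two long chains of compound 1 and still stands level with it, so on this read-out the level of effect does not depend on the group at this position. The earlier pair showed only that the drawn geometry of one double bond left the number unchanged, and it said nothing about whether the group had to be present; nothing given here explains why its loss leaves the number in place.

Going by these compounds, what an amine, a carboxylic acid or a shorter chain would do at this aromatic carbon remains open. So does whether the one long chain that compound 3 keeps can be lost as well.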